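This account rests on a few compounds, and the source may have more. Where it says the series, first, only, none or still open, it means among the compounds named here.

In an assay on mitochondria (strain BALB/c) for inhibition of glycerol-3-phosphate acyltransferase 1, mitochondrial (Mus musculus), read by scintillation counting, with a stated time of 10 min (a lower number here means a stronger inhibitor, a higher number a weaker inhibitor), three compounds have been measured: compound 1 `CCCCCCCCS(=O)(=O)Nc1cc(-c2ccccc2Cl)ccc1C(=O)O`, giving 26900 nM; compound 2 `CCCCCCCCS(=O)(=O)Nc1cc(-c2cccc(Cl)c2)ccc1C(=O)O`, giving 13800 nM; and compound 3 `CCCCCCCCS(=O)(=O)Nc1ccc(-c2ccccc2Cl)cc1C(=O)O`, giving 14400 nM.

Compound 2 differs from compound 1 by 3-chlorophenyl in place of 2-chlorophenyl on an aromatic carbon, and that step was a 1.9-fold lower number from compound 1 to compound 2 (0.29 log units; within the scatter). Compound 4 `CCCCCCCCS(=O)(=O)Nc1ccc(-c2cccc(Cl)c2)cc1C(=O)O` is not yet measured; it differs from compound 3 by 3-chlorophenyl in place of 2-chlorophenyl on an aromatic carbon. This is the same kind of change as before, not the same one: in compound 1 the place is meta to a large group and para to a carboxy group, while in compound 3 it is meta to a carboxy group and para to a large group. How the cores of compound 1 and compound 3 differ is not broken down here; their two values in this assay lie within the usual scatter of each other. For compound 4 a step of similar size is expected, a 1.8-fold lower number from compound 3 to compound 4 (0.26 log units; within the scatter), resting on the earlier step of a 1.9-fold lower number from compound 1 to compound 2 (0.29 log units; within the scatter). Compound 4 is therefore estimated at 8000 nM, with a likely range from 3500 nM to 18000 nM.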

Compound 4, half-maximal inhibitory concentration: 8900 nM
Compound 4: middle estimate off by 1.1-fold (0.05 log units), on the low side, and the stated range covers the measured number.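

In this assay, 3-chlorophenyl in place of 2-chlorophenyl on the core of compound 3 gave a 1.6-fold lower number from compound 3 to compound 4 (0.21 log units; within the scatter). Set beside the same change on the core of compound 1, the two steps agree: the same change on two cores in this assay, a 1.9-fold lower number (0.29 log units; within the scatter) from compound 1 to compound 2 and a 1.6-fold lower number (0.21 log units; within the scatter) from compound 3 to compound 4, 1.2-fold (0.08 log units) apart, within the scatter of two such steps. The change therefore carried across these two cores with a step of similar size, but each step lies within the scatter on its own, so the pair does not show that the change has a real effect on either core, and it says nothing about any other core.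

The compounds shown leave open what an unsubstituted phenyl or a bromophenyl would give in that place. They also leave open whether the result would hold with a longer chain, or with an amine in place of the carboxy group.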